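The source may report more compounds than this note shows. Statements on the series, on what has been measured and on what is new or still open speak of the compounds shown alone.

Of the compounds shown here, two have been measured so far. Compound 1 `COc1nc(-c2cc3ccccc3o2)cc(-c2ccc(Cl)cc2)c1C#N` in a functional assay on aorta (strain Wistar) for inhibition, with Thoracic aorta (Rattus norvegicus) as the target (a higher number here means a weaker inhibitor, a lower number a stronger inhibitor), gives 286000 nM. Compound 2 `COc1nc(-c2cc3ccccc3o2)cc(-c2ccc(Cl)cc2Cl)c1C#N` in this assay gives 322000 nM. Compound 2 stands with the higher of the two numbers, yet the gap between them is small: a 1.1-fold higher number from compound 1 to compound 2 (0.05 log units; within the scatter). On the numbers shown, the two compounds cannot be told apart.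

Compound 3 `COc1nc(-c2cc3ccccc3o2)cc(-c2ccc(Br)cc2)c1C#N` has not yet been measured. It differs from compound 2 in one place: 4-bromophenyl in place of 2,4-dichlorophenyl on an aromatic carbon. Within the data shown here, only one measured step bears on this change, a 1.1-fold higher number from compound 1 to compound 2 (0.05 log units; within the scatter), in which a chloro took the place of a hydrogen on an aromatic carbon, and that step stayed within the scatter. Compound 3 carries a single halogen on that ring, as compound 1 does, with bromine where compound 1 has chlorine. Nothing measured here speaks for a move beyond the scatter in this assay, so the expected step is a 1.1-fold lower number from compound 2 to compound 3 (0.05 log units; within the scatter). For compound 3 in this assay the estimate is 290000 nM, with an expected range from 150000 nM to 600000 nM.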

Compound 3, half-maximal inhibitory concentration: 298000 nM
For compound 3 the middle estimate is 1.0-fold (0.01 log units) below the measured one; low and high end bracket the measured number.
By their numbers in this assay, from the lowest: compounds 1, 3 and 2 (each within the scatter of the next).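

Within this assay the exchange of 2,4-dichlorophenyl for 4-bromophenyl on this carbon, opposite the ring nitrogen, gives a 1.1-fold lower number from compound 2 to compound 3 (0.03 log units; within the scatter) and so changes two things at once, the number of halogens on the ring and the kind of halogen, without separating the two compounds. The direct exchange of chloro for bromo, with nothing else altered, gives a 1.0-fold higher number from compound 1 to compound 3 (0.02 log units; within the scatter) and adds what the earlier pair could not show: at this ring position, bromine and chlorine cannot be told apart in this assay, just as one chlorine and two could not. All three compounds therefore sit within the scatter of one another, and no measurement at hand explains this result.

On these data alone, all three compounds carry a halogen-bearing phenyl ring, so it remains open whether an amine or a carboxylic acid on that ring, or a different ring in its place, would give a step beyond the scatter. The methoxy group, the nitrile and the 1-benzofuran-2-yl group are the same throughout, which leaves open what a longer chain in place of the methoxy group, for example, would do to the number.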